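The source may hold more compounds than are shown below. What is called first, only, known or untested is meant among the compounds shown, and "the series" means these compounds.

Working notes on the series built on the shared core of compound 1 `Cc1ccc(NC2=CC(=O)c3c(nc4n3[C@H]3OC[C@@H](O)[C@H]3OC4)C2=O)cc1C`. Among the compounds with values here, in a functional assay on MCF7 cells (Homo sapiens) for inhibition, read by sulforhodamine B assay (a lower number here means a stronger inhibitor, a higher number a weaker inhibitor), compound 1 gives 4950 nM, the only number in the set. The two further values are limits. Compound 2 `O=C1C(Nc2ccc(C(F)(F)F)cc2)=CC(=O)c2c1nc1n2[C@H]2OC[C@@H](O)[C@H]2OC1` stands at > 4000 nM, a limit of the assay. Compound 3 `CCOc1ccccc1NC1=CC(=O)c2c(nc3n2[C@H]2OC[C@@H](O)[C@H]2OC3)C1=O` likewise sits at > 4000 nM, also a limit. The step that the limit leaves unreadable from compound 1 to compound 2 is thus not readable, nor is a step that the limit leaves unreadable from compound 1 to compound 3, nor a step that the two limits leave unreadable from compound 2 to compound 3; all three compounds cluster near (the limit of > 4000 nM in this assay, at which 2 of the 3 values shown sit), with compound 1 itself close to it.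

Compound 4 `CCCN(CCC)C1=CC(=O)c2c(nc3n2[C@H]2OC[C@@H](O)[C@H]2OC3)C1=O` differs from compound 1 in one place: dipropylamino in place of (3,4-dimethylphenyl)amino on a double-bonded ring carbon. Within the data shown here, none of the measured steps bears on this change: each of them swaps one group for another on the amine nitrogen, and none is readable in size. No direction of step beyond the scatter can therefore be expected for a 1.2-fold higher number from compound 1 to compound 4 (0.08 log units; within the scatter), which is estimated to be small. Compound 4 is estimated in this assay at 6000 nM, within 2000 nM to 20000 nM, with a fair chance that only a limit is reported.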

Compound 4, half-maximal inhibitory concentration: > 16000 nM
Compound 4: only a limit was reported; the forecaster's own chance of this, stated with the estimate: 50%; at least 2.6-fold (0.42 log units) between middle value and limit.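

Dipropylamino in place of (3,4-dimethylphenyl)amino on the double-bonded ring carbon gives the only readable step in the series in this assay: an at least 3.2-fold higher number from compound 1 to compound 4 (0.50 log units; beyond the scatter). The value of compound 4, > 16000 nM, is a limit and not a number: the limit of > 16000 nM in this assay, at which 1 of the 4 values shown sits. The change removes the six-membered aromatic ring and the hydrogen-bond donor together, and it shows a direction at this position, whereas the steps among the aryl groups on the amine nitrogen in compounds 1, 2 and 3 cannot be read.

The compounds shown do not separate the part played by the aromatic ring, the hydrogen-bond donor and the two propyl chains. Going by these compounds, what a propylamino group, which keeps the amine hydrogen and has no aromatic ring, would give in this assay stays open.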